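Cyclobutyl side chain: phenyl for tert-butyl in compound 2

The compounds below may be only part of what the source reports. "The series", "measured", "known", "first", "only" and "open" are said of these compounds alone.

Measured so far:
compound 1, `CCCCC(C)(C)[C@H](O)/C=C/[C@H]1CCC(=O)N1CCSc1nc(C(=O)O)cs1`: 0.91 nM
compound 2, `CC(C)(C)CCC1([C@H](O)/C=C/[C@H]2COC(=O)N2CCSc2nc(C(=O)O)cs2)CCC1`: 3700 nM
compound 3, `CC(C)(CCCCF)[C@H](O)/C=C/[C@H]1COC(=O)N1CCSc1nc(C(=O)O)cs1`: 5.7 nM

In an assay on isolated protein for agonist activity at prostaglandin E2 receptor EP2 subtype (Homo sapiens) (a lower number here means that less compound is needed, a higher number that more compound is needed for the effect), compound 2 stands highest of the three numbers. Its nearest neighbour is compound 3, reached by a 650-fold lower number from compound 2 to compound 3 (2.81 log units; beyond the scatter), where the 1-(3,3-dimethylbutyl)cyclobutyl unit is replaced by an open 5-fluoro-1,1-dimethylpentyl chain. Among the measured compounds shown here, compound 1, with an open chain and a lactam in the core, sits further away still, and no step to it is measured.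

Compound 4, `O=C(O)c1csc(SCCN2C(=O)OC[C@@H]2/C=C/[C@@H](O)C2(CCc3ccccc3)CCC2)n1`, is the next candidate. Its difference from compound 2 is phenyl in place of tert-butyl on a saturated chain carbon, two bonds along the chain from a saturated ring carbon; cut one bond further out it reads neopentyl to benzyl, or 3,3-dimethylbutyl to phenethyl. The cyclobutyl unit stays in place. For the measured compounds named here, no measured step covers a tert-butyl to phenyl exchange, and the one large step known here removed the ring rather than altering the chain end. The expectation for compound 4 in this assay is therefore a number close to that of compound 2, with wide uncertainty in either direction, so an estimated step of a 2.5-fold lower number from compound 2 to compound 4 (0.39 log units; beyond the scatter). Compound 4 is estimated at 1500 nM, range 200 nM to 12000 nM.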

Compound 4, half-maximal effective concentration: 160 nM
Estimate against measurement, compound 4: 9.4-fold (0.97 log units) above; the whole stated range lies above it.
By their numbers in this assay, from the lowest: compound 1; then compound 3; then compound 4; then compound 2.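

In this assay the end of the side chain turns out to matter even with the cyclobutyl unit in place: phenyl in place of tert-butyl gives a large step on its own (a 23-fold lower number from compound 2 to compound 4 (1.36 log units; beyond the scatter)). The earlier step exchanged the whole 1-(3,3-dimethylbutyl)cyclobutyl unit for an open chain, so it could not separate the chain end from the ring; this change shows that the high number of compound 2 is not fixed by the cyclobutyl unit alone. No supporting data bear on the reason for this step.

Still open, going by these compounds, is whether a cyclohexyl or pyridyl group at the chain end would give a step of similar size, and whether a longer chain carrying the phenyl would lower the number further. Also open, on these data alone, is whether the cyclobutyl unit itself costs anything once phenyl is present.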